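Phenyl for amino on a carbonyl in a thioxoimidazolidine series

A few compounds are considered here, and "the series" means these few. Any claim that something is new, unique, unknown or untested is made for them only; others in the source may bear on it.

Three compounds share a thioxoimidazolidine core and were tested in a functional assay on NCI-H322M cells (Homo sapiens) for inhibition, read by sulforhodamine B assay, with a stated time of 48 h; a lower number here means a stronger inhibitor of growth, a higher number a weaker inhibitor of growth. Compound 1 `N#C/C(=C\N1CCN(C(=O)c2ccco2)C1=S)C(N)=O` gives 17600 nM there. Compound 2 `O=CN1CCN(C(=O)c2ccco2)C1=S` gives 18500 nM, and compound 3 `O=CN1CCN(c2cc(Cl)cc(Cl)c2)C1=S` gives 19700 nM. Compound 1 has the lowest of the three numbers, but both compound 2 and compound 3 lie within the scatter of it, so the three cannot be ordered.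

Compound 4 `N#C/C(=C\N1CCN(C(=O)c2ccco2)C1=S)C(=O)c1ccccc1` has not yet been tested. Its difference from compound 1 is phenyl in place of amino on a carbonyl carbon, the carbamoyl becoming benzoyl. Within the data shown here, no measured pair shows such a change, so the step is expected to be small, with the step of a 1.2-fold lower number from compound 1 to compound 4 (0.07 log units; within the scatter) expected to stay near the scatter. Compound 4 is therefore estimated at 15000 nM, between 5000 nM and 45000 nM.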

Compound 4, concentration for 50% growth inhibition: 23400 nM
The estimate for compound 4 lay 1.6-fold (0.19 log units) below the measured number, and the stated range covers the measured number.
By their numbers in this assay, from the lowest: compounds 1, 2, 3 and 4 (each within the scatter of the next).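

In this assay, phenyl in place of amino on a carbonyl carbon gives a 1.3-fold higher number from compound 1 to compound 4 (0.12 log units; within the scatter) and so does not move the number beyond the scatter. At this position, then, carbamoyl and benzoyl cannot be told apart, even though the amino group's hydrogen-bond donor leaves and an aromatic ring enters. Nothing available accounts for this result.

The compounds shown leave open whether a methylamino group, a hydroxyl or a chlorophenyl on this carbonyl carbon would give a step beyond the scatter. They also leave open whether replacing the nitrile would do so.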